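Methoxy for Methyl Across Two Pairs of Compounds

The source may report more compounds than this note shows. Statements on the series, on what has been measured and on what is new or still open speak of the compounds shown alone.

Compound 1 `Cc1ccc(-c2cc(/N=C3/NC(=O)CS3)cs2)cc1` in a functional assay on HT-29 cells (Homo sapiens) for cytotoxicity, read by MTT assay, with a stated time of 72 h (on this read-out higher numbers stand for weaker inhibition and lower numbers for stronger inhibition), gives > 50000 nM, which is a limit of the assay and not a number.
Compound 2 `COc1ccc(-c2cc(/N=C3/NC(=O)CS3)cs2)cc1` in this assay gives > 50000 nM, again a limit.
Compound 3 `COc1cccc(N2C(=O)CS/C2=N\c2csc(-c3ccc(C)cc3)c2)c1` in this assay gives > 50000 nM, also a limit.

The change from compound 1 to compound 2 is methoxy in place of methyl on an aromatic carbon. Its step is a step that the two limits leave unreadable from compound 1 to compound 2, because of the limit of > 50000 nM in this assay, at which 3 of the 3 values shown sit. The same change, (methoxy in place of methyl on an aromatic carbon), is made from compound 3 to the unmeasured compound 4 `COc1ccc(-c2cc(/N=C3\SCC(=O)N3c3cccc(OC)c3)cs2)cc1`; the two place descriptions agree word for word, so it is the same change in both pairs. The two cores differ by 3-methoxyphenyl in place of hydrogen on an amide-type nitrogen in a ring, a step that the two limits leave unreadable from compound 1 to compound 3. Among the compounds with values here, since every value so far is a limit, the step from compound 3 to compound 4 is expected to be a step that the limit leaves unreadable from compound 3 to compound 4, with compound 4 estimated at 60000 nM, most likely again reported only as a limit in this assay.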

Compound 4, half-maximal inhibitory concentration: 11700 nM
Beside the measured number, compound 4's estimate is 5.1-fold (0.71 log units) above it; measured number below the stated range.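

In this assay, methoxy in place of methyl gives an at least 4.2-fold lower number from compound 3 to compound 4 (0.63 log units; beyond the scatter), and 3-methoxyphenyl in place of the amide hydrogen gives an at least 4.2-fold lower number from compound 2 to compound 4 (0.63 log units; beyond the scatter). Within the data shown here, the same methoxy change on the core of compound 1 cannot be read, and neither can the other steps among the earlier compounds, because both ends of each step sit at a limit of the assay: the limit of > 50000 nM in this assay, at which 3 of the 4 values shown sit. The methoxy change therefore lowers the number on the core of compound 3, but nothing shows that it carries over to the core of compound 1.

Still open, as far as these compounds go, is whether an amine or a carboxylic acid in place of the methoxy would also give a measurable number on the core of compound 3. Also open, from the compounds shown here alone, is whether a longer chain on the amide-type nitrogen could stand in for 3-methoxyphenyl.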